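Chloro to trifluoromethyl: cytotoxicity expected for compound 4

This account rests on a few compounds, and the source may have more. Where it says the series, first, only, none or still open, it means among the compounds named here.

Compound 1 `NC(=S)N1CCc2c(OCCCCCOc3ccc(Cl)cc3)cccc21` gives > 50000 nM in an ADME assay on Huh-7 cells (Homo sapiens) for cytotoxicity; a higher number here means that more compound is tolerated, a lower number that less compound is tolerated.
Compound 2 `O=C(NC(=S)N1CCc2c(OCCCCCOc3ccc(Cl)cc3)cccc21)Oc1ccccc1` gives > 50000 nM in this assay.
Compound 3 `O=C(NC(=S)N1CCc2c(OCCCCCOc3ccc(Cl)cc3)cccc21)c1ccc(Cl)cc1` gives 21700 nM in this assay.

The values of compound 1 and compound 2 are limits of this assay, not numbers. Among the measured compounds shown here, compound 3 is the only compound of the three with a measured number, and the two steps towards it, an at least 2.3-fold lower number from compound 1 to compound 3 (0.36 log units; beyond the scatter) and an at least 2.3-fold lower number from compound 2 to compound 3 (0.36 log units; beyond the scatter), both run in the direction of less compound being tolerated; the step that the two limits leave unreadable from compound 1 to compound 2 cannot be read because of the limit of > 50000 nM in this assay, at which 2 of the 3 values shown sit.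

Compound 4 `O=C(NC(=S)N1CCc2c(OCCCCCOc3ccc(Cl)cc3)cccc21)c1ccc(C(F)(F)F)cc1` differs from compound 3 in one place: trifluoromethyl in place of chloro on an aromatic carbon. For the measured compounds named here, no measured step exchanges one substituent on that ring for another, so none of the three steps bears directly on this change; the measured steps only show that a carbonyl-linked aryl group on the thiourea nitrogen, as in compound 3, goes with a readable number rather than a limit. Compound 4 keeps that group, and the expected step of a 1.1-fold lower number from compound 3 to compound 4 (0.04 log units; within the scatter) is therefore small, within the scatter. Compound 4 is estimated at 20000 nM, with a range from 7000 nM to 50000 nM in this assay.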

Compound 4, half-maximal cytotoxic concentration: 32700 nM
Beside the measured number, compound 4's estimate is 1.6-fold (0.21 log units) below it; low and high end bracket the measured number.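

At this place, on an aromatic carbon of a six-membered aromatic ring of carbon only, para to a large group, this assay now has its first exchange of one substituent for another: a 1.5-fold higher number from compound 3 to compound 4 (0.18 log units; within the scatter), so this assay does not tell trifluoromethyl and chloro apart here. Compound 4 joins compound 3 in giving a number rather than a limit, so the carbonyl-linked aryl group gives a readable value with either substituent. From the two compounds without that aryl group, the steps read an at least 1.5-fold lower number from compound 2 to compound 4 (0.18 log units; that floor lies within the scatter) and an at least 1.5-fold lower number from compound 1 to compound 4 (0.18 log units; that floor lies within the scatter), so the separation beyond the scatter printed for compound 3 is not established for compound 4.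

On these data alone, whether another group at this place, such as an amine, a carboxylic acid or a methoxy group, would shift the number beyond the scatter stays open. How far compound 1 and compound 2 truly lie from the two compounds with numbers, and from each other, cannot be read: the limit of > 50000 nM in this assay, at which 2 of the 4 values shown sit.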